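A few compounds are considered here, and "the series" means these few. Any claim that something is new, unique, unknown or untested is made for them only; others in the source may bear on it.

Compound 2 `COc1ccc(C(=O)/C=C/c2cc(-c3cc(OC)c(OC)c(OC)c3)n[nH]2)cc1` gives 1450 nM in a functional assay on UO-31 cells (Homo sapiens) for inhibition, read by sulforhodamine B assay, with a stated time of 48 h (a higher number here means a weaker inhibitor of growth, a lower number a stronger inhibitor of growth), and compound 1 `COc1cc(-c2cc(/C=C/C(=O)c3ccc(N)cc3)[nH]n2)cc(OC)c1OC` gives 1360 nM in this assay. Going by the values given here, the two numbers sit close together: the step of a 1.1-fold higher number from compound 1 to compound 2 (0.03 log units; within the scatter) is the only measured step in this set, and it lies within the scatter, so compound 2 stands level with compound 1 rather than apart from it.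

Compound 3 `COc1cc(-c2cc(/C=C/C(=O)c3ccc(F)c(F)c3)[nH]n2)cc(OC)c1OC` differs from compound 2 by 3,4-difluorophenyl in place of 4-methoxyphenyl on a carbonyl carbon. Among the compounds with values here, the one measured step bears on it only loosely: it changed a group on the same aryl ring, leaving the number essentially unmoved, but no measured pair exchanges the whole aryl ring as this change does. Within the data shown here, with the single relevant step flat, the step of a 1.0-fold higher number from compound 2 to compound 3 (0.01 log units; within the scatter) is expected to be small and of uncertain direction, with a wide range allowed. Compound 3 is therefore estimated at 1500 nM, between 500 nM and 4500 nM.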

Compound 3, concentration for 50% growth inhibition: 2630 nM
Beside the measured number, compound 3's estimate is 1.8-fold (0.24 log units) below it; the range from low to high includes it.
By their numbers in this assay, from the lowest: compounds 1, 2 and 3 (each within the scatter of the next).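

Replacing the whole aryl ring on the carbonyl carbon, not just one group on it, still gives no step beyond the scatter in this assay. With 3,4-difluorophenyl in place of 4-methoxyphenyl the result is a 1.8-fold higher number from compound 2 to compound 3 (0.26 log units; within the scatter), and with 3,4-difluorophenyl in place of 4-aminophenyl it is a 1.9-fold higher number from compound 1 to compound 3 (0.29 log units; within the scatter). Compounds 1, 2 and 3 thus show that this place accepts all three aryl groups, including one with no hydrogen-bond acceptor, without a step that can be told from the scatter. No measurement given here accounts for these numbers.

As far as these compounds go, it remains open whether a carboxylic acid or a longer amine chain on this aryl ring would move the number beyond the scatter. The compounds shown also say nothing about changes elsewhere on the shared core.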